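The source may hold more compounds than are shown below. What is called first, only, known or untested is meant among the compounds shown, and "the series" means these compounds.

Three members of the series have been run in a functional assay on Bel-7402 cells (Homo sapiens) for cytotoxicity, read by MTT assay; on this read-out higher numbers stand for weaker inhibition and lower numbers for stronger inhibition. Compound 1 `COc1cccc(/C=C/C(=O)c2sc(Nc3cccc(C)c3)nc2C)c1` gives only the assay limit, > 25000 nM, a limit and not a number. Compound 3 `COc1cccc(/C=C/C(=O)c2sc(Nc3ccccc3C)nc2C)c1` likewise gives only the limit > 25000 nM. Compound 2 `COc1cc(/C=C/C(=O)c2sc(Nc3ccc(Cl)c(Cl)c3)nc2C)cc(OC)c1OC` also reaches no more than the limit > 25000 nM, so where it stands is known only as a limit. Among the compounds with values here, the single one-place step, a step that the two limits leave unreadable from compound 1 to compound 3, cannot be read, as every value shown sits at the limit of > 25000 nM in this assay, at which 3 of the 3 values shown sit. Compound 4 `COc1cc(/C=C/C(=O)c2sc(Nc3ccc(C)cc3)nc2C)cc(OC)c1OC` differs from compound 2 by 4-methylphenyl in place of 3,4-dichlorophenyl on a nitrogen on an aromatic ring. Within the data shown here, no measured step bears on this change, and all three values shown sit at the limit. Compound 4 is therefore expected to remain at the limit as well, with a step that the limit leaves unreadable from compound 2 to compound 4 not beyond scatter, estimated at 30000 nM, range 10000 nM to 100000 nM.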

Compound 4, half-maximal inhibitory concentration: > 25000 nM
Compound 4: a limit, no number; the forecaster's own chance of this, stated with the estimate: 85%; the middle value lies beyond the limit too.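

No step can be read between compound 2 and compound 4, since both give only a limit and not a number: the limit of > 25000 nM in this assay, at which 4 of the 4 values shown sit.

The compounds shown leave open which structural change, if any, would give a measurable value in this assay.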